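The source may hold more compounds than are shown below. What is called first, only, known or untested is meant among the compounds shown, and "the series" means these compounds.

Among the compounds with values here, in a functional assay on CAKI-1 cells (Homo sapiens) for inhibition, read by sulforhodamine B assay, with a stated time of 48 h (on this read-out lower numbers stand for stronger inhibition of growth and higher numbers for weaker inhibition of growth), compound 1 (`O=C(Cc1csc2nc(-c3ccc(Br)cc3)cn12)N/N=C/c1ccccc1`) gives 81300 nM, the higher of the two numbers so far, while compound 2 (`O=C(Cc1csc2nc(-c3ccc(Br)cc3)cn12)N/N=C/c1ccccc1O`) gives 2400 nM. Compound 3 (`O=C(Cc1csc2nc(-c3ccc(Br)cc3)cn12)N/N=C/c1ccc(Cl)cc1Cl`) has 2,4-dichlorophenyl in place of phenyl on a carbon with a double bond to nitrogen. Within the data shown here, only one measured step bears on this change, the large 34-fold lower number from compound 1 to compound 2 (1.53 log units; beyond the scatter), with hydroxy in place of hydrogen on an aromatic carbon. It involves a different group, so a smaller move in the same direction is expected in this assay. The expected step is a 3.3-fold lower number from compound 1 to compound 3 (0.51 log units; beyond the scatter). For compound 3 the estimated value is 25000 nM, with an expected range of 5000 nM to 95000 nM.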

Compound 3, concentration for total growth inhibition: > 100000 nM
Compound 3 gave a limit, no number; the forecaster's own chance of this, stated with the estimate: 15%; at least 4.0-fold (0.60 log units) between middle value and limit.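

Compound 3 gave only a limit in this assay, not a number: the limit of > 100000 nM in this assay, at which 1 of the 3 values shown sits. Read against phenyl, 2,4-dichlorophenyl gives an at least 1.2-fold higher number from compound 1 to compound 3 (0.08 log units; that floor lies within the scatter), so this substitution on the ring does not repeat the gain seen with hydroxy, although that floor lies within the scatter. Read against 2-hydroxyphenyl, the same limit gives an at least 41-fold higher number from compound 2 to compound 3 (1.61 log units; beyond the scatter), so the gain at this position holds for hydroxy but does not extend to every substituted phenyl.

On these data alone, how far the true value of compound 3 lies past its limit remains open. So does whether a methoxy group or an amine in place of the hydroxy of compound 2 would keep that gain.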